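A few compounds are considered here, and "the series" means these few. Any claim that something is new, unique, unknown or untested is made for them only; others in the source may bear on it.

Working notes on the series.

For the measured compounds named here, compound 2 `COc1ccc(-c2cc(=O)c3cc(OCCCCCCN4CCC(O)CC4)ccc3o2)cc1` gives 332 nM in an assay on isolated protein (Cavia porcellus) with Sigma non-opioid intracellular receptor 1 (Homo sapiens) as the target, read by radioligand binding (on this read-out lower numbers stand for stronger inhibition and higher numbers for weaker inhibition), the higher of the two numbers so far. Going by the values given here, compound 1 `O=c1cc(-c2ccccc2)oc2ccc(OCCCCCCN3CCC(O)CC3)cc12`, which lacks the methoxy group, gives 121 nM; the single measured step in the set, a 2.7-fold higher number from compound 1 to compound 2 (0.44 log units; beyond the scatter), is the only comparison available.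

Compound 3 `O=c1cc(C2CCCCC2)oc2ccc(OCCCCCCN3CCC(O)CC3)cc12` is not yet measured. The change from compound 2 is cyclohexyl in place of 4-methoxyphenyl on an aromatic carbon. Among the compounds with values here, no measured step covers an exchange of the whole aromatic substituent for a saturated ring, so the step of a 2.7-fold higher number from compound 1 to compound 2 (0.44 log units; beyond the scatter) bears on it only indirectly: it shows that this position tolerates a change of that size without leaving the range of the series. Within the data shown here, with no closer precedent, the expected step is small in either direction, a 1.7-fold lower number from compound 2 to compound 3 (0.22 log units; within the scatter), leaning toward compound 1 rather than further away. The estimate for compound 3 in this assay is therefore 200 nM, with a range of 50 nM to 800 nM.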

Compound 3, half-maximal inhibitory concentration: 46 nM
Beside the measured number, compound 3's estimate is 4.3-fold (0.64 log units) above it; the measured number lies below the stated range.
By their numbers in this assay, from the lowest: compound 3; then compound 1; then compound 2.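

In this assay, cyclohexyl at this position on an aromatic carbon next to the ring oxygen gives a 7.2-fold lower number from compound 2 to compound 3 (0.86 log units; beyond the scatter), and against the unsubstituted phenyl it gives a 2.6-fold lower number from compound 1 to compound 3 (0.42 log units; beyond the scatter), so an aromatic ring at this place is not needed for binding in this series. The second step separates the exchange of the ring itself from the loss of the methoxy group, and compound 3 now has the lowest number of the three, with its steps to both others beyond the scatter. No supporting data bear on why the saturated ring gives the lower number.

The compounds shown leave open how a smaller saturated ring such as cyclopentyl or an open-chain group such as tert-butyl would read at this place. They also leave open whether a methoxy group on the cyclohexyl ring would raise the number, as it does on the phenyl ring.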